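Halogen pattern swap on the benzyl group

The compounds below may be only part of what the source reports. "The series", "measured", "known", "first", "only" and "open" are said of these compounds alone.

The series shares one core. Compound 1 `CCCn1c(=O)c2c(nc(-n3cc(I)cn3)n2Cc2ccccc2)n(CCC)c1=O` in an in vitro assay on HEK293 cells for displacement of a labelled ligand from adenosine receptor A2b (Homo sapiens) (a higher number here means a weaker inhibitor, a lower number a stronger inhibitor), gives only a limit, > 5800 nM. Compound 2 `CCCn1c(=O)c2nc(-c3cnn(Cc4ccc(F)cc4F)c3)[nH]c2n(CCC)c1=O` gives 700 nM in this assay, the lowest of the two numbers shown. Compound 3 `CC(C)Cn1c(=O)c2nc(-c3cnn(Cc4cccc(F)c4)c3)[nH]c2n(CC(C)C)c1=O` gives 990 nM in this assay, a value within the scatter of compound 2, so no order can be read between these two. Compound 4 `CCCn1c(=O)c2nc(-c3cnn(Cc4cc(F)ccc4Cl)c3)[nH]c2n(CCC)c1=O` carries 2-chloro-5-fluorophenyl in place of 2,4-difluorophenyl on a saturated chain carbon bound to an aromatic nitrogen. Among the compounds with values here, no step between measured compounds is available, and compound 2 and compound 3 differ in more than one place, so only their two values can be set side by side. The step from compound 2 to compound 4 is expected at a 1.1-fold lower number from compound 2 to compound 4 (0.03 log units; within the scatter), none beyond the scatter. Compound 4 is therefore expected at 650 nM, between 250 nM and 1700 nM.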

Compound 4, inhibition constant: 4800 nM
For compound 4 the middle estimate is 7.4-fold (0.87 log units) below the measured one; the whole stated range lies below it.
By their numbers in this assay, from the lowest: compounds 2 and 3 (each within the scatter of the next); then compound 4. At a limit, above all of these: compound 1.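

Replacing 2,4-difluorophenyl with 2-chloro-5-fluorophenyl on a saturated chain carbon bound to an aromatic nitrogen gives a 6.9-fold higher number from compound 2 to compound 4 (0.84 log units; beyond the scatter). Within the data shown here, this is the first single-place step, and it shows that the halogen pattern on this benzyl group is not neutral, even though the heavy-atom count stays the same. No supplied evidence bears on the reason for this loss.

Among these compounds, the single swap does not separate the effect of adding chlorine from that of changing the halogen pattern. From the compounds shown here alone, how a methoxy group, an amine or a carboxylic acid on this phenyl ring would read also remains open.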